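A few compounds are considered here, and "the series" means these few. Any claim that something is new, unique, unknown or untested is made for them only; others in the source may bear on it.

Compound 1 `CC(C)C(Nc1nccs1)c1ccc(-c2ccc3cccc(F)c3c2)[nH]c1=O`: 9.4 nM
Compound 2 `CC(C)C(Cc1nnn[nH]1)c1ccc(-c2ccc3cccc(F)c3c2)[nH]c1=O`: 34 nM
Compound 3 `CC(C)C(Nc1nnc[nH]1)c1ccc(-c2ccc3cccc(F)c3c2)[nH]c1=O`: 22 nM

These three compounds share one core and differ only in the group attached to the saturated chain carbon bound to an aromatic carbon and a saturated chain carbon. In an assay on CHO cells for displacement of a labelled ligand from prostaglandin E2 receptor EP3 subtype (Homo sapiens), read by radioligand binding (on this read-out higher numbers stand for weaker inhibition and lower numbers for stronger inhibition), compound 3 stands second highest of the three numbers; its nearest neighbour is compound 2, while the clearer gap is a 2.3-fold higher number from compound 1 to compound 3 (0.37 log units; beyond the scatter).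

Compound 4 `CC(C)C(Cc1noc(=O)[nH]1)c1ccc(-c2ccc3cccc(F)c3c2)[nH]c1=O` has not been measured. Its change from compound 3 is a group of 7 heavy atoms (3 carbon, 2 nitrogen, 2 oxygen; one five-membered aromatic ring with 3 hetero atoms) in place of a group of 6 heavy atoms (2 carbon, 4 nitrogen; one five-membered aromatic ring with 3 hetero atoms), on a saturated chain carbon bound to an aromatic carbon and a saturated chain carbon. The new group, like the group in compound 2, is joined to the chain carbon through a saturated carbon rather than through an amine nitrogen, and it again carries a five-membered ring with one hydrogen-bond donor.

Among the measured compounds shown here, two measured steps bear on this. Moving from an amine-linked ring to a carbon-linked ring gave a 3.6-fold higher number from compound 1 to compound 2 (0.56 log units; beyond the scatter). Exchanging the carbon-linked ring of compound 2 for the amine-linked ring of compound 3 gave a 1.5-fold lower number from compound 2 to compound 3 (0.19 log units; within the scatter), which is within the scatter. Compound 4 is therefore expected to land near compound 2, with a step of a 1.6-fold higher number from compound 3 to compound 4 (0.20 log units; within the scatter), pointing toward a somewhat higher number but possibly within the scatter. The estimate for compound 4 in this assay is 35 nM, within a range from 15 nM to 85 nM.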

Compound 4, inhibition constant: 34 nM
Compound 4: middle estimate off by 1.0-fold (0.01 log units), on the high side, and the stated range covers the measured number.
By their numbers in this assay, from the lowest: compound 1; then compounds 3, 2 and 4 (each within the scatter of the next).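

In this assay, a second carbon-linked ring on the saturated chain carbon gives no change at the digits printed from compound 2 to compound 4 (within the scatter), so at this position the tetrazole ring can give way to the new ring, with its different mix of nitrogen and oxygen and its added double bond outside the ring, without a change that can be read. The (1,3-thiazol-2-yl)amino group still stands apart, with a 3.6-fold higher number from compound 1 to compound 4 (0.56 log units; beyond the scatter) matching a 3.6-fold higher number from compound 1 to compound 2 (0.56 log units; beyond the scatter) in size, yet a 1.5-fold higher number from compound 3 to compound 4 (0.19 log units; within the scatter) stays within the scatter, and so the amine link alone does not set the number: compound 3 has that link and goes against any such rule. No measurement shown offers a reason for these steps.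

Going by these compounds, what stays open is whether the thiazole ring would keep the number of compound 1 if joined through a 1,3-thiazol-2-ylmethyl group instead of its amine. Also open, on these data alone, is whether a ring is needed at all on this chain carbon, since a carboxylic acid or a plain amine there would test that directly.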